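The source may hold more compounds than are shown below. What is called first, only, known or untested is meant among the compounds shown, and "the series" means these compounds.

Of the compounds shown here, two have been tested in a functional assay on MV4-11 cells (Homo sapiens) for cytotoxicity, read by colorimetric assay and MTT assay, with a stated time of 3 days, tested at 1 uM; on this read-out higher numbers stand for a weaker effect at the one concentration tested and lower numbers for a stronger effect. Compound 1 `COc1ccc(-n2cc(-c3ccccc3)c(-c3ccc4c(c3)NC(=O)CO4)n2)cc1` gives 106%, and compound 2 `O=C1COc2ccc(-c3[nH]c(-c4c[nH]c5ncccc45)nc3-c3ccccc3)cc2N1` gives 111%. Of the two numbers shown, compound 2 carries the larger one, yet its gap to compound 1 falls within the usual scatter, so the two cannot be told apart, and neither shows a clear effect at the single concentration used. Compound 3 `O=C1COc2ccc(-c3[nH]c(-c4ccc(F)cc4)nc3-c3ccccc3)cc2N1` has not been measured yet. It differs from compound 2 in one place: a group of 7 heavy atoms (6 carbon, 1 fluorine; one six-membered aromatic ring of carbon only) in place of a group of 9 heavy atoms (7 carbon, 2 nitrogen; one five-membered aromatic ring with 1 hetero atom, one six-membered aromatic ring with 1 hetero atom), on an aromatic carbon. For the measured compounds named here, no step between measured compounds is known, so there is nothing from which to read how such a change moves the number. Going only by compound 2 with its 111%, the step from compound 2 to compound 3 is expected to be a number 6 percentage points lower from compound 2 to compound 3 (within the scatter), that is, none beyond the scatter. Compound 3 is therefore estimated at 105%, with a range from 90% to 120%.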

Compound 3, a percentage reported as activity, at one concentration (the size of the read-out at that concentration, not a potency): 108%
Beside the measured number, compound 3's estimate is 3 percentage points below it; the range from low to high includes it.
By their numbers in this assay, from the lowest: compounds 1, 3 and 2 (each within the scatter of the next).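

At the aromatic carbon between two ring nitrogen atoms, placing a 4-fluorophenyl group where the two-ring group stood gives a number 3 percentage points lower from compound 2 to compound 3 (within the scatter) in this assay at this position. For the compounds shown here, this is the first measured step here, and it shows that a carbon-only ring can take the place of a two-ring group holding ring nitrogens and a hydrogen-bond donor without the read-out moving beyond the scatter. No measurement at hand offers an explanation for this result.

Going by these compounds, whether a much smaller group on this carbon, such as a methyl or an amine, or a carboxylic acid on the phenyl ring would move the number beyond the scatter remains open. The compounds shown also leave open which changes to the shared core, if any, would bring a clear effect at the one concentration tested.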